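This account rests on a few compounds, and the source may have more. Where it says the series, first, only, none or still open, it means among the compounds named here.

Measured so far:
compound 1 `CCCC(Oc1ccc(-n2cc(C#N)cn2)cc1)c1ccc(C(=O)NCCC(=O)O)cc1`: 4100 nM
compound 2 `CCCC(Oc1ccc(-n2cc(Cl)cn2)cc1)c1ccc(C(=O)NCCC(=O)O)cc1`: 1100 nM

In an assay on cells for displacement of a labelled ligand from Glucagon receptor (Homo sapiens), in the presence of a further agent that is not named here (a lower number here means a stronger inhibitor, a higher number a weaker inhibitor), compound 2 holds the lower of the two numbers; the other, compound 1, gives 4100 nM. Within the data shown here, the only measured step is a 3.7-fold lower number from compound 1 to compound 2 (0.57 log units; beyond the scatter). Compound 3 `CCCC(Oc1ccc(-n2cc(C(F)(F)F)cn2)cc1)c1ccc(C(=O)NCCC(=O)O)cc1` differs from compound 2 by trifluoromethyl in place of chloro on an aromatic carbon. That measured step concerns cyano against chloro and does not involve trifluoromethyl, so it bears only loosely on the present change. Compound 3 is therefore expected to show a step of a 1.4-fold lower number from compound 2 to compound 3 (0.14 log units; within the scatter), which would sit within the scatter. Compound 3 is estimated at 800 nM, with a range from 300 nM to 2500 nM.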

Compound 3, inhibition constant in the Glucagon receptor assay: 890 nM
For compound 3 the middle estimate is 1.1-fold (0.05 log units) below the measured one; low and high end bracket the measured number.
By their numbers in the Glucagon receptor assay, from the lowest: compounds 3 and 2 (each within the scatter of the next); then compound 1.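

In the Glucagon receptor assay compound 3 gives 890 nM and compound 2 gives 1100 nM, so this carbon of the five-membered aromatic ring accepts trifluoromethyl and chloro alike (a 1.2-fold lower number from compound 2 to compound 3 (0.09 log units; within the scatter)), while compound 1, the nitrile compound, gives 4100 nM and remains apart (a 4.6-fold lower number from compound 1 to compound 3 (0.66 log units; beyond the scatter)). In a physicochemical assay for lipophilicity, using the shake flask method, at pH 7.4 (on this read-out lower numbers stand for lower lipophilicity and higher numbers for higher lipophilicity), compound 2 gives 2.6 and compound 3 gives 2.4, so the same exchange also leaves the two compounds unseparated (a number 0.20 log units lower from compound 2 to compound 3 (within the scatter)). Nothing available explains why these two groups read alike in binding while the nitrile does not. As far as these compounds go, whether a methyl, a methoxy or an amine at this position would match chloro and trifluoromethyl stays open. So does whether their match would hold on another core.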